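The source may hold more compounds than are shown below. What is called first, only, known or untested is meant among the compounds shown, and "the series" means these compounds.

Measured compounds:
- compound 1 `COc1cc(/C=C/C(=O)c2cccc(-n3cc(-c4ccc(Cl)cc4)[nH]c3=O)c2)cc(OC)c1OC`: "not active" (no number reported)
- compound 2 `O=C(/C=C/c1cccc(O)c1)c1cccc(-n2cc(-c3ccccc3)[nH]c2=O)c1`: 24800 nM
- compound 3 `O=C(/C=C/c1cccc(O)c1)c1cccc(-n2cc(-c3ccc(Cl)cc3)[nH]c2=O)c1`: 2310 nM

In a functional assay on NCI-H226 cells (Homo sapiens) for inhibition (on this read-out higher numbers stand for weaker inhibition of growth and lower numbers for stronger inhibition of growth), compound 1 is reported only as "not active" (no number reported), so no number places it against the other two; it stands outside the measured range, at the weak end. Compound 2 gives 24800 nM and compound 3 gives 2310 nM in this assay, a difference of an 11-fold lower number from compound 2 to compound 3 (1.03 log units; beyond the scatter).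

Compound 4 `COc1ccc(-c2cn(-c3cccc(C(=O)/C=C/c4cc(OC)c(OC)c(OC)c4)c3)c(=O)[nH]2)cc1` differs from compound 1 by methoxy in place of chloro on an aromatic carbon. Among the compounds with values here, no measured pair shows this exact exchange. Within the data shown here, the one measured step, chloro in place of hydrogen, is large, which suggests that what sits at this position of the ring matters, but it says nothing about methoxy in particular, and compound 1 itself gives no number to start from. The expectation for compound 4 is therefore uncertain and leans toward weak growth inhibition, with a real chance that this assay again reports no number. Compound 4 is estimated at 30000 nM, within 5000 nM to 150000 nM.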

Compound 4, concentration for 50% growth inhibition: 35200 nM
Compound 4: the middle estimate sits 1.2-fold (0.07 log units) below what was measured; the measured number falls inside the stated range.
By their numbers in this assay, from the lowest: compound 3; then compounds 2 and 4 (each within the scatter of the next).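

In this assay compound 1 is reported as "not active" (no number reported) and so offers no number to set against compound 4, which means no step can be read between them. Still open is how 4-chlorophenyl and 4-methoxyphenyl compare on this shared core, and nothing shown here offers an explanation.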